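Removing a Methyl from the Oxindole Ring of Compound 2

The source may hold more compounds than are shown below. What is called first, only, known or untested is meant among the compounds shown, and "the series" means these compounds.

Measured compounds:
compound 1 `COc1cc2c(/C=C3/C(=O)Nc4ccc(Cl)cc43)c(Cl)n(Cc3cc(OC)c(OC)c(OC)c3)c2cc1C` — 3720 nM
compound 2 `COc1cc2c(cc1C)NC(=O)/C2=C/c1c(Cl)n(Cc2cc(OC)c(OC)c(OC)c2)c2cc(C)c(OC)cc12` — 30900 nM

Of the compounds shown here, two have been tested so far in a functional assay on cells (Cancer cell lines, Homo sapiens) for cytotoxicity, with a stated time of 48 h; on this read-out lower numbers stand for stronger inhibition of growth and higher numbers for weaker inhibition of growth. Compound 1 `COc1cc2c(/C=C3/C(=O)Nc4ccc(Cl)cc43)c(Cl)n(Cc3cc(OC)c(OC)c(OC)c3)c2cc1C` gives 3720 nM, while compound 2 `COc1cc2c(cc1C)NC(=O)/C2=C/c1c(Cl)n(Cc2cc(OC)c(OC)c(OC)c2)c2cc(C)c(OC)cc12` gives 30900 nM, the highest of the two numbers; the two structures differ in several places at once, so their values are simply shown side by side.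

Compound 3 `COc1ccc2c(c1)/C(=C\c1c(Cl)n(Cc3cc(OC)c(OC)c(OC)c3)c3cc(C)c(OC)cc13)C(=O)N2` is not yet measured. It differs from compound 2 by a single change, hydrogen in place of methyl on an aromatic carbon of the six-membered carbon ring of the fused system, ortho to a methoxy group. For the measured compounds named here, no step between measured compounds isolates this kind of change, so no direction can be read from the data. A change of one heavy atom is expected to move the number little, if at all beyond the scatter, with a slight lean toward a lower number.

Compound 3 is expected to give 20000 nM in this assay, within 7000 nM to 60000 nM, a step of a 1.5-fold lower number from compound 2 to compound 3 (0.19 log units; within the scatter) that is estimated, not measured.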

Compound 3, concentration for 50% growth inhibition: 33100 nM
Compound 3: the middle estimate sits 1.7-fold (0.22 log units) below what was measured, within the range that was stated.
By their numbers in this assay, from the lowest: compound 1; then compounds 2 and 3 (each within the scatter of the next).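

In this assay, hydrogen in place of methyl on an aromatic carbon, ortho to a methoxy group, gives a 1.1-fold higher number from compound 2 to compound 3 (0.03 log units; within the scatter), so at this position on the oxindole ring of compound 2 the methyl group makes no difference that this read-out can resolve. For the compounds shown here, compound 3 also provides the first single-place comparison with compound 1: methoxy in place of chloro on an aromatic carbon gives an 8.9-fold higher number from compound 1 to compound 3 (0.95 log units; beyond the scatter), a step beyond the scatter that shows this second change, unlike the loss of the methyl, does register in this assay. Nothing in hand explains either step.

The compounds shown leave open whether the insensitivity to the methyl group extends to other groups at that carbon, such as an ethyl group, an amine or a carboxylic acid. They also leave open whether fluoro or bromo would track chloro or methoxy at the carbon where compound 1 and compound 3 differ, and so whether the step belongs to chloro specifically.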